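The source may hold more compounds than are shown below. What is called first, only, known or untested is meant among the compounds shown, and "the series" means these compounds.

Compound 2 `CCN1CCN(c2cccc3c2CN([C@H](CCCNC(=O)c2c(C)n[nH]c2C)c2ccc(OC)c(OC)c2)C3=O)CC1` and compound 1 `CCN1CCN(c2cccc3c2CN([C@H](CCCNCc2cccs2)c2ccc(OC)c(OC)c2)C3=O)CC1` share one core and differ only at the amine nitrogen of the chain. In a functional assay on CHO-K1 cells for antagonist activity at Urotensin-2 receptor (Rattus norvegicus), read by FLIPR and calcium flux, with a stated time of 1 h (a higher number here means a weaker inhibitor, a lower number a stronger inhibitor), compound 1 gives 6 nM, and in this assay compound 2 gives 16 nM. Among the compounds with values here, compound 2 therefore stands with the higher of the two numbers measured, and the only measured step, a 2.7-fold higher number from compound 1 to compound 2 (0.43 log units; beyond the scatter), lies beyond the scatter.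

Compound 3 `CCN1CCN(c2cccc3c2CN([C@H](CCCNS(=O)(=O)c2c[nH]cn2)c2ccc(OC)c(OC)c2)C3=O)CC1` is not yet measured. It differs from compound 2 at the same place: (1H-imidazol-4-yl)sulfonyl in place of (3,5-dimethyl-1H-pyrazol-4-yl)carbonyl on an amine nitrogen.

Within the data shown here, the one step that bears on this change is the exchange at that amine nitrogen, a 2.7-fold higher number from compound 1 to compound 2 (0.43 log units; beyond the scatter), which shows that the group carried there moves the number by a modest amount. Among the measured compounds shown here, no measured step compares a carbonyl with a sulfonyl at this position, so the direction is uncertain. The expectation is a small step, if any, from compound 2 to compound 3 in this assay, estimated as a 1.9-fold higher number from compound 2 to compound 3 (0.27 log units; within the scatter). For compound 3 the estimated value in this assay is 30 nM, with a range from 8 nM to 120 nM.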

Compound 3, half-maximal inhibitory concentration: 23 nM
Estimate against measurement, compound 3: 1.3-fold (0.12 log units) above; low and high end bracket the measured number.
By their numbers in this assay, from the lowest: compound 1; then compounds 2 and 3 (each within the scatter of the next).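

In this assay, the exchange of (3,5-dimethyl-1H-pyrazol-4-yl)carbonyl for (1H-imidazol-4-yl)sulfonyl on the amine nitrogen gives a 1.4-fold higher number from compound 2 to compound 3 (0.16 log units; within the scatter) and so leaves the number within the scatter, even though the link to the nitrogen and the ring both differ. Set against the (thiophen-2-yl)methyl group, the same sulfonyl group gives a 3.8-fold higher number from compound 1 to compound 3 (0.58 log units; beyond the scatter), which places compound 3 with compound 2 on the same side of compound 1, and among these three compounds compound 1 keeps the lowest number, with neither of the others going against that order. No measurement offered here explains either step.

The link and the ring change together from compound 2 to compound 3, so these compounds leave open how much each contributes, a question that a (1H-imidazol-4-yl)carbonyl group or a (3,5-dimethyl-1H-pyrazol-4-yl)sulfonyl group on the same nitrogen could address. Also open, as far as these compounds go, is whether the lower number of compound 1 belongs to the thiophene ring or to its methylene link, which a benzyl group on that nitrogen could begin to test.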